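A few compounds are considered here, and "the series" means these few. Any claim that something is new, unique, unknown or untested is made for them only; others in the source may bear on it.

Measured so far in an assay for inhibition of histone-lysine N-methyltransferase EZH2 variant Y641N (Homo sapiens), read by scintillation counting, with a stated time of 60 min, in the presence of a further agent that is not named here; on this read-out higher numbers stand for weaker inhibition and lower numbers for stronger inhibition:
- compound 1 `COc1cc(C)[nH]c(=O)c1CN1CCc2c(Cl)cc(-c3c(C)noc3C)c(Cl)c2C1=O`: 0.15 nM
- compound 2 `COC(c1cc(Cl)c2c(c1Cl)C(=O)N(Cc1c(C)cc(C)[nH]c1=O)CC2)C1CCS(=O)(=O)CC1`: 93 nM; 0.35 nM (2 entries)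
- compound 3 `Cc1cc(C)c(CN2CCc3c(Cl)cc([C@H](CO)[C@@H]4CCCO4)c(Cl)c3C2=O)c(=O)[nH]1`: 10 nM

Compound 3 holds the highest of the two single numbers in this assay; compound 1 lies well beyond the scatter below it, and compound 2 has no single number, only the spread shown by the several entries of compound 2 in this assay, 93 nM; 0.35 nM (2 entries).

Compound 4 `Cc1cc(C)c(CN2CCc3c(Cl)cc(-c4c(C)noc4C)c(Cl)c3C2=O)c(=O)[nH]1` is not yet measured. It differs from compound 3 by a group of 7 heavy atoms (5 carbon, 1 nitrogen, 1 oxygen; one five-membered aromatic ring with 2 hetero atoms) in place of a group of 8 heavy atoms (6 carbon, 2 oxygen; one five-membered non-aromatic ring with 1 hetero atom), on an aromatic carbon. For the measured compounds named here, the group that enters is the one carried by compound 1, whose value of 0.15 nM stands far under that of compound 3, so a large step down is expected in this assay. For compound 4 the expected step is a 33-fold lower number from compound 3 to compound 4 (1.52 log units; beyond the scatter), giving an estimate of 0.3 nM with a range from 0.1 nM to 1.5 nM.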

Compound 4, inhibition constant: 1.15 nM
The estimate for compound 4 lay 3.8-fold (0.58 log units) below the measured number; measured number inside the range.
By their numbers in this assay, from the lowest: compound 1; then compound 4; then compound 3.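

In this assay, 3,5-dimethyl-1,2-oxazol-4-yl on this aromatic carbon, with the rest of the compound unchanged, gives an 8.7-fold lower number from compound 3 to compound 4 (0.94 log units; beyond the scatter), so an aromatic ring with no hydrogen-bond donor and no stereocentre serves better here than the group it replaces. With this group held, methyl in place of methoxy gives a 7.7-fold higher number from compound 1 to compound 4 (0.88 log units; beyond the scatter), so the low number seen earlier did not rest on the 3,5-dimethyl-1,2-oxazol-4-yl group alone. No measurement shown gives a reason for either step.

Still open, going by these compounds, is how an amine or a carboxylic acid on this aromatic carbon would compare with compound 4. Also open, on these data alone, is whether methoxy in place of methyl gives a step of like size when the group of compound 3 is present.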